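The compounds below may be only part of what the source reports. "The series", "measured", "known", "first", "only" and "open" are said of these compounds alone.

Compound 2, `FC(F)(F)c1ccc(CSc2nc(Nc3ccccc3Cl)c3ccccc3n2)cc1`, stands at the edge of what a functional assay on MCF7 cells (Homo sapiens) for cytotoxicity, read by MTT assay, with a stated time of 72 h (a lower number here means a stronger inhibitor, a higher number a weaker inhibitor), can report: in this assay compound 2 gives > 50000 nM, which is a limit and not a number. Compound 1, `FC(F)(F)c1ccc(CSc2nc(Nc3ccccc3C(F)(F)F)c3ccccc3n2)cc1`, sits at the same place, since in this assay compound 1 gives > 50000 nM, again a limit. Two of the three values therefore rest at the limit of > 50000 nM in this assay, at which 2 of the 3 values shown sit. Only compound 3, `FC(F)(F)c1ccc(CSc2nc(Nc3ccc(Cl)cc3)c3ccccc3n2)cc1`, yields a number: in this assay compound 3 gives 21500 nM. The step that the two limits leave unreadable from compound 1 to compound 2 cannot be read, as both ends are limits. The steps of an at least 2.3-fold lower number from compound 1 to compound 3 (0.36 log units; beyond the scatter) and an at least 2.3-fold lower number from compound 2 to compound 3 (0.36 log units; beyond the scatter) both run toward a lower number, and each is at least modest.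

Compound 4, `FC(F)(F)c1ccc(CSc2nc(Nc3ccc(C(F)(F)F)cc3)c3ccccc3n2)cc1`, has not been measured. It differs from compound 2 by 4-(trifluoromethyl)phenyl in place of 2-chlorophenyl on a nitrogen on an aromatic ring. The group that leaves, 2-chlorophenyl, is the same one that leaves on the way from compound 2 to compound 3, and the group that enters, 4-(trifluoromethyl)phenyl, resembles the 4-chlorophenyl that enters there. The step of an at least 2.3-fold lower number from compound 2 to compound 3 (0.36 log units; beyond the scatter) is thus the closest guide, and a lower number of at least modest size is expected. Compound 4 is expected to give about 25000 nM in this assay, within 8000 nM to 60000 nM. This estimate corresponds to an expected step of an at least 2.0-fold lower number from compound 2 to compound 4 (0.30 log units; that floor lies within the scatter).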

Compound 4, half-maximal inhibitory concentration: 5100 nM
For compound 4 the middle estimate is 4.9-fold (0.69 log units) above the measured one; measured number below the stated range.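

Going by these compounds alone, on the nitrogen on an aromatic ring, 4-(trifluoromethyl)phenyl goes further than 4-chlorophenyl: in this assay, trifluoromethyl in place of chloro on the aromatic carbon gives a 4.2-fold lower number from compound 3 to compound 4 (0.62 log units; beyond the scatter), the first step with a number at both ends. Trifluoromethyl as such does not keep a compound at the limit, since the same group carried as 4-(trifluoromethyl)phenyl rather than 2-(trifluoromethyl)phenyl gives an at least 9.8-fold lower number from compound 1 to compound 4 (0.99 log units; beyond the scatter), and replacing 2-chlorophenyl with 4-(trifluoromethyl)phenyl gives an at least 9.8-fold lower number from compound 2 to compound 4 (0.99 log units; beyond the scatter). These last two steps are floors and not full sizes, because one end of each is a limit: the limit of > 50000 nM in this assay, at which 2 of the 4 values shown sit.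

The compounds shown leave open whether a nitrile or a methoxy group in place of the trifluoromethyl of compound 4 would keep, lower or raise the number. They also leave open how much the group on the sulfur, which is the same in all four compounds, contributes to the values seen.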